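Methoxy to hydroxy on the aryl of compound 2

The compounds below may be only part of what the source reports. "The series", "measured", "known", "first", "only" and "open" are said of these compounds alone.

Measured so far in a functional assay on K562 cells (Homo sapiens) for cytotoxicity, read by sulforhodamine B assay, with a stated time of 48 h, tested at 100 nM; a lower number here means a stronger effect, a higher number a weaker effect of the compound at the concentration tested:
compound 1, `COc1cc(C)cc(-c2c(-c3ccnc(-c4ccc(N(C)C)cc4)c3)cnn2CC#N)c1`, 7%
compound 2, `COc1cc(C)cc(-c2nn(CC#N)cc2-c2ccnc(-c3ccc(N(C)C)cc3)c2)c1`, 10%

Both numbers are low, so both compounds show a strong effect at the concentration tested. Going by the values given here, compound 2 stands within the scatter of compound 1, so the two cannot be told apart on these numbers; no step between them is counted here, and nothing in the pair points to a trend.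

Compound 3, `Cc1cc(O)cc(-c2nn(CC#N)cc2-c2ccnc(-c3ccc(N(C)C)cc3)c2)c1`, is not yet measured in this assay. It differs from compound 2 in one place: hydrogen in place of methyl on an oxygen on an aromatic ring. The change is small in atom count and touches only the oxygen on the aromatic ring.

Among the compounds with values here, no measured step exists to calibrate such a change, so the expectation rests on the level of compound 2 alone. A small step is expected, a number 5 percentage points higher from compound 2 to compound 3 (within the scatter), most likely towards a somewhat weaker effect, but not reliably beyond the scatter. For compound 3 the expected value is 15%, with a range of 4% to 40%.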

Compound 3, a percentage reported as activity, at one concentration (the size of the read-out at that concentration, not a potency): 80%
Estimate against measurement, compound 3: 65 percentage points below; measured number outside the range, above it.
By their numbers in this assay, from the lowest: compounds 1 and 2 (each within the scatter of the next); then compound 3.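

In this assay, going by these compounds alone, the change from methoxy to hydroxy on the aryl group gives a number 70 percentage points higher from compound 2 to compound 3 (beyond the scatter) and is the first step beyond the scatter. The methyl on this oxygen therefore carries real weight at the concentration tested: a change of one heavy atom, on an oxygen on an aromatic ring, separates a strong effect from a weak one. Nothing available on these compounds accounts for the size of this step.

Still open, as far as these compounds go, is whether the effect depends on the methyl itself or on the absence of the hydroxy hydrogen, which a longer chain on the oxygen, as in ethoxy, or an amine or a fluorine in place of the methoxy, would help to separate. Also open, from the compounds shown here alone, is whether the same change made on compound 1 gives a step of similar size, and how far this single-concentration read-out reflects potency across the series.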